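From 2-isopropylphenyl to 2,4,6-trimethylphenyl on the shared core

A few compounds are considered here, and "the series" means these few. Any claim that something is new, unique, unknown or untested is made for them only; others in the source may bear on it.

Two compounds in the series have been taken through an ADME assay on L02 cells (Homo sapiens) for inhibition, read by CCK-8 assay, with a stated time of 48 h (a lower number here means a stronger inhibitor of growth, a higher number a weaker inhibitor of growth), so far. Within the data shown here, compound 1 `CN1CCN(c2ccc(Nc3ncc(Cl)c(NCc4ccc(C(F)(F)F)cc4)n3)nc2)CC1` gives 26200 nM as the only number available. Compound 2 `CC(C)c1ccccc1Nc1nc(Nc2ccc(N3CCN(C)CC3)cn2)ncc1Cl` gives "not determined" (no result reported) in the same test, so it has no position on the scale and offers no numerical starting point for the next comparison.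

Compound 3 `Cc1cc(C)c(Nc2nc(Nc3ccc(N4CCN(C)CC4)cn3)ncc2Cl)c(C)c1` has not yet been measured. The structural change 2,4,6-trimethylphenyl in place of 2-isopropylphenyl on a nitrogen on an aromatic ring places 2,4,6-trimethylphenyl in place of 2-isopropylphenyl on a nitrogen on an aromatic ring, and the two compounds have the same atoms, joined differently.

Among the measured compounds shown here, no measured pair shows what such a change does. The size of the step in this assay cannot be read from the data, and no step beyond the usual scatter is expected, in either direction. With compound 1 at 26200 nM as the sole anchor, a weak growth inhibitor is the expected outcome, with wide uncertainty.

Compound 3 is estimated at 22000 nM with an expected range of 7000 nM to 60000 nM in this test.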

Compound 3, concentration for 50% growth inhibition: 20500 nM
The estimate for compound 3 lay 1.1-fold (0.03 log units) above the measured number; the range from low to high includes it.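

In this assay, the position now carries two groups with readable numbers: with 2,4,6-trimethylphenyl in place of 4-(trifluoromethyl)benzyl on a nitrogen on an aromatic ring, the result is a 1.3-fold lower number from compound 1 to compound 3 (0.11 log units; within the scatter), so this exchange does not separate the two compounds in this test. The change from 2-isopropylphenyl to 2,4,6-trimethylphenyl, two groups with the same count of heavy atoms, still cannot be read as a step, since compound 2 has no number to set against compound 3. Nothing at hand accounts for the level shared by compound 1 and compound 3.

Open, from the compounds shown here alone, is whether any group on this nitrogen moves the number beyond the usual scatter, since the two readable groups give one level and a single comparison cannot show how wide the tolerance is. Going by these compounds, a carboxylic acid or a primary amine carried on the phenyl ring of compound 3 would test the position with groups of a different kind from the carbon-only 2,4,6-trimethylphenyl, and the outcome of such a change is unknown.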